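The compounds below may be only part of what the source reports. "The series", "measured", "known", "first", "only" and "open" are said of these compounds alone.

Measured so far:
- compound 1, `CCn1ccnc1-c1cc(OC)c(OC)c(OC)c1`: > 100000 nM
- compound 2, `COc1cc(-c2nccn2-c2ccc3sccc3c2)cc(OC)c1OC`: 16800 nM
- compound 3, `COc1cc(-c2nccn2-c2ccc3cc[nH]c3c2)cc(OC)c1OC`: 7500 nM

In a functional assay on MDA-MB-231 cells (Homo sapiens) for antiproliferative activity, read by MTT assay, with a stated time of 72 h (a lower number here means a stronger inhibitor, a higher number a weaker inhibitor), compound 1 is reported only as a limit of the assay, > 100000 nM, with no number behind it. This is the case for (the limit of > 100000 nM in this assay, at which 1 of the 3 values shown sits). Compound 2 and compound 3 carry larger groups on the same aromatic nitrogen; in this assay compound 2 gives 16800 nM and compound 3 gives 7500 nM, both numbers rather than limits. Among the measured compounds shown here, no step between two measured compounds that differ in a single place is available here.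

The compound not yet measured is compound 4, `COc1cc(-c2nccn2-c2ccc(Br)cc2)cc(OC)c1OC`. It differs from compound 1 by 4-bromophenyl in place of ethyl on an aromatic nitrogen. Compound 2 and compound 3 show that a ring on that nitrogen goes together with a measurable number in this assay, so a step in the direction of stronger inhibition is expected, of a size that carries compound 4 well clear of the limit at which compound 1 sits. For compound 4 the step that is expected is an at least 5.0-fold lower number from compound 1 to compound 4 (0.69 log units; beyond the scatter). Compound 4 is therefore estimated at 20000 nM, within a range from 6000 nM to 70000 nM.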

Compound 4, half-maximal inhibitory concentration: 8400 nM
Beside the measured number, compound 4's estimate is 2.4-fold (0.38 log units) above it; measured number inside the range.
By their numbers in this assay, from the lowest: compounds 3, 4 and 2 (each within the scatter of the next, the first and the last beyond it). At a limit, above all of these: compound 1.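

In this assay, among the compounds shown here, putting 4-bromophenyl in place of ethyl on the aromatic nitrogen gives the first step that can be read at this position, an at least 11-fold lower number from compound 1 to compound 4 (1.07 log units; beyond the scatter). Compound 2 and compound 3 had already linked a ring on this nitrogen to a measurable number, but neither could be set against compound 1 as a change in one place, and compound 4 now shows that a single six-membered aromatic ring bearing bromine also gives a measurable number, within the usual scatter of both of theirs. The true size of the step remains unknown, and the printed figure is only a minimum, because compound 1 is reported as a limit and not as a number: the limit of > 100000 nM in this assay, at which 1 of the 4 values shown sits.

The compounds shown cannot separate the part played by the ring from the part played by the bromine, a question that a plain phenyl group on the same nitrogen would address. They also leave open how a longer chain such as butyl, or a phenyl ring carrying an amine or a carboxylic acid, would behave at this position.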